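The source may report more compounds than this note shows. Statements on the series, on what has been measured and on what is new or still open speak of the compounds shown alone.

Measured in a functional assay on PC-3 cells (Homo sapiens) for inhibition, read by sulforhodamine B assay; a lower number here means a stronger inhibitor of growth, a higher number a weaker inhibitor of growth:
- Compound 1 `COc1cc(-c2ccc(-c3ccc(-c4nc5cc(C)ccc5[nH]4)cc3)cc2)cc(OC)c1OC`: 180 nM
- Compound 2 `COc1cc(-c2ccc(-c3ccc(-c4nc5ccccc5[nH]4)cc3)cc2)cc(OC)c1OC`: 9720 nM
- Compound 3 `COc1ccc(-c2ccc(-c3ccc(-c4nc5c(O)cccc5[nH]4)cc3)cc2)cc1OC`: 1240 nM

Of these three, compound 1 has the lowest number, compound 2 the highest, and compound 3 falls between them with 1240 nM. Compound 4 `COc1cc(-c2ccc(-c3ccc(-c4nc5c(O)cccc5[nH]4)cc3)cc2)cc(OC)c1OC` differs from compound 3 by a single change, methoxy in place of hydrogen on an aromatic carbon, ortho to a methoxy group. Within the data shown here, no measured step covers this change directly. The only one available, a 54-fold higher number from compound 1 to compound 2 (1.73 log units; beyond the scatter), is large, but it is hydrogen in place of methyl at another place. Among the measured compounds shown here, it shows only that one small change can move the number far in this set. Compound 1, at 180 nM, and compound 2, at 9720 nM, already carry the methoxy pattern of compound 4, yet they lie on either side of compound 3. No direction can therefore be expected in this assay, and the wide range reflects that. The expected step is a 1.0-fold higher number from compound 3 to compound 4 (0.02 log units; within the scatter), which means no shift beyond the scatter. Compound 4 is estimated at 1300 nM, with an expected range of 250 nM to 6000 nM.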

Compound 4, concentration for 50% growth inhibition: 170 nM
For compound 4 the middle estimate is 7.6-fold (0.88 log units) above the measured one, outside the stated range (below it).
By their numbers in this assay, from the lowest: compounds 4 and 1 (each within the scatter of the next); then compound 3; then compound 2.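

In this assay methoxy in place of hydrogen, ortho to a methoxy group, gives a 7.3-fold lower number from compound 3 to compound 4 (0.86 log units; beyond the scatter) and so reads as a real gain at this position when the hydroxy group is present. Adding the hydroxy group gives a 57-fold lower number from compound 2 to compound 4 (1.76 log units; beyond the scatter) with the methoxy pattern held constant, which shows that the hydroxy group also matters strongly. Swapping 5-methyl-1H-benzimidazol-2-yl for 4-hydroxy-1H-benzimidazol-2-yl gives a 1.1-fold lower number from compound 1 to compound 4 (0.02 log units; within the scatter) and leaves the two compounds level within the scatter, so either group lifts the unsubstituted compound 2 by a similar margin.

Going by these compounds, whether an amine or a carboxylic acid in place of the hydroxy group, or an ethoxy group in place of the added methoxy, would hold this level stays open. Nothing given here accounts for the size of these steps.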